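Dichlorophenyl Triazole Variant in a Weakly Antiproliferative Series

The source may hold more compounds than are shown below. What is called first, only, known or untested is meant among the compounds shown, and "the series" means these compounds.

Compound 1 `N#CC1=C(N)Oc2c(c3nc4ccccc4nc3c3ccccc23)C12C(=O)N(Cc1cnnn1-c1ccc(Cl)cc1)c1ccccc12`: in a functional assay on MCF7 cells (Homo sapiens) for antiproliferative activity, read by MTT assay, with a stated time of 48 h (on this read-out higher numbers stand for weaker inhibition and lower numbers for stronger inhibition), compound 1 gives > 50000 nM, a limit of the assay rather than a number.
Compound 2 `N#CC1=C(N)Oc2c(c3nc4ccccc4nc3c3ccccc23)C12C(=O)N(Cc1cnnn1-c1cccc(Cl)c1)c1ccccc12`: in this assay compound 2 gives 43600 nM.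
Compound 3 `CC(=O)Nc1ccc(-n2nncc2CN2C(=O)C3(C(C#N)=C(N)Oc4c3c3nc5ccccc5nc3c3ccccc43)c3ccccc32)cc1`: in this assay compound 3 gives > 50000 nM, again only a limit.

Compound 3 thus stands at the limit of > 50000 nM in this assay, at which 2 of the 3 values shown sit. Only a limit is known for it. Within the data shown here, the single numbered value in the set, that of compound 2, lies close to that limit, so the three measured compounds cannot be ordered against each other.

Compound 4 `N#CC1=C(N)Oc2c(c3nc4ccccc4nc3c3ccccc23)C12C(=O)N(Cc1cnnn1-c1ccc(Cl)c(Cl)c1)c1ccccc12` differs from compound 3 by 3,4-dichlorophenyl in place of 4-acetamidophenyl on an aromatic nitrogen. Among the measured compounds shown here, two measured steps touch this position. The step of an at least 1.1-fold higher number from compound 2 to compound 3 (0.05 log units; that floor lies within the scatter) runs from a chlorophenyl to the acetamidophenyl that now leaves, and the step of an at least 1.1-fold lower number from compound 1 to compound 2 (0.05 log units; that floor lies within the scatter) compares two chlorophenyls; both lie within the scatter. The step that the two limits leave unreadable from compound 1 to compound 3 adds nothing readable. Across compound 1, compound 2 and compound 3 the shared core remains weakly active whatever sits on the aromatic nitrogen, so no step beyond the scatter is expected in this assay in either direction. The expected step is an at least 1.0-fold lower number from compound 3 to compound 4 (0.01 log units; that floor lies within the scatter). Compound 4 is therefore estimated at 48000 nM, with a range from 20000 nM to 150000 nM, and a fair chance that the assay again reports only a limit.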

Compound 4, half-maximal inhibitory concentration: > 50000 nM
Compound 4 ended at the assay's limit (the forecaster's own chance of this, stated with the estimate: 55%); middle value at least 1.0-fold (0.01 log units) away from the limit.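

The 3,4-dichlorophenyl group combines the chloro substituents of the 3-chlorophenyl and 4-chlorophenyl groups in one compound. Against the 3-chlorophenyl group, the added chloro on an aromatic carbon gives an at least 1.1-fold higher number from compound 2 to compound 4 (0.05 log units; that floor lies within the scatter), so this change shows no effect that can be told from the scatter, although the true size of the step stays unknown. The steps from compound 1 and from compound 3 to compound 4 cannot be read, as both ends of each are limits, and a phenyl with two chloro substituents on this aromatic nitrogen joins the others at the top of the measurable range: the limit of > 50000 nM in this assay, at which 3 of the 4 values shown sit.

The compounds shown leave open whether any group at this position can bring the shared core clearly inside the measurable range of this assay, and how far compound 1, compound 3 and compound 4 really lie beyond their limits. A phenyl bearing an amine or a carboxylic acid, or a longer alkyl chain in place of the phenyl on this aromatic nitrogen, would put that first question to a different kind of group.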